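From butyl to tert-butyl in compound 4

The source may report more compounds than this note shows. Statements on the series, on what has been measured and on what is new or still open speak of the compounds shown alone.

In a functional assay on the whole organism for inhibition, with Rattus norvegicus as the target (a higher number here means that more compound is needed for the effect, a lower number that less compound is needed), compound 1 `CCCc1ccc(CC(C)(Oc2ccc(C(C)C)cc2)C(=O)O)cc1` gives 0.5 mg/kg, compound 2 `CC(C)c1ccc(CC(C)(Oc2ccc(C(C)C)cc2)C(=O)O)cc1` gives 5 mg/kg and compound 3 `CCCCc1ccc(CC(C)(Oc2ccc(C(C)C)cc2)C(=O)O)cc1` gives 1 mg/kg. The measurements show a 2.0-fold higher number from compound 1 to compound 3 (0.30 log units; within the scatter), and they also show a 5.0-fold lower number from compound 2 to compound 3 (0.70 log units; beyond the scatter). Compound 3 therefore cannot be told apart from compound 1, but it is clearly separated from compound 2.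

Compound 4 `CC(C)c1ccc(OC(C)(Cc2ccc(C(C)(C)C)cc2)C(=O)O)cc1` has the same atoms as compound 3, joined differently: tert-butyl in place of butyl on an aromatic carbon. The change is tert-butyl in place of butyl on an aromatic carbon, para to a large group.

Within the data shown here, no measured compound carries tert-butyl, so the nearest guide is the one measured swap of a straight chain for a branched one, isopropyl in place of propyl: a 10-fold higher number from compound 1 to compound 2 (1.00 log units; beyond the scatter). The swap from isopropyl to butyl points the same way: a 5.0-fold lower number from compound 2 to compound 3 (0.70 log units; beyond the scatter). A clear move towards a higher number is therefore expected, somewhat smaller than the first of these, and the expected step is a 4.0-fold higher number from compound 3 to compound 4 (0.60 log units; beyond the scatter). The estimate for compound 4 is 4 mg/kg, within an expected range of 1 mg/kg to 15 mg/kg.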

Compound 4, dose for half-maximal effect: 5 mg/kg
Estimate against measurement, compound 4: 1.3-fold (0.10 log units) below; the measured number falls inside the stated range.
By their numbers in this assay, from the lowest: compounds 1 and 3 (each within the scatter of the next); then compounds 2 and 4 (each within the scatter of the next).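

In this assay, the branched groups now stand apart from both straight chains, not just from one: a 5.0-fold higher number from compound 3 to compound 4 (0.70 log units; beyond the scatter), and a 10-fold higher number from compound 1 to compound 4 (1.00 log units; beyond the scatter). Butyl and tert-butyl have the same count of carbon, so among these four compounds it is branching, not the number of carbons, that goes with the higher numbers, and no compound shown goes against this. Going from isopropyl to tert-butyl gives no change at the digits printed from compound 2 to compound 4 (within the scatter), and adding one methyl leaves the number within the scatter on both the straight and the branched group: the same change on two cores in this assay, a 2.0-fold higher number (0.30 log units; within the scatter) from compound 1 to compound 3 and no change at the digits printed (within the scatter) from compound 2 to compound 4, 2.0-fold (0.30 log units) apart, within the scatter of two such steps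

Going by these compounds, whether the pattern extends to a ring such as cyclopropyl or cyclohexyl, or to a chain holding an ether oxygen such as methoxymethyl, remains open. These whole-organism doses also do not say why branching goes with a higher number.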